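A few compounds are considered here, and "the series" means these few. Any claim that something is new, unique, unknown or untested is made for them only; others in the source may bear on it.

Compound 3 `CC(C(=O)N1CCN(c2cccc(F)c2)CC1)N1C(=O)CCC1=O` gives 100% in a functional assay on the whole organism (strain Swiss) with Mus musculus as the target, in the maximal electroshock model, with a stated time of 0.25 h, at a dose of 300 mg/kg by the intraperitoneal route (on this read-out higher numbers stand for a stronger effect at the one dose given and lower numbers for a weaker effect), the highest of the three numbers in hand. Compound 1 `COc1cccc(N2CCN(C(=O)C(C)N3C(=O)CCC3=O)CC2)c1` gives 75% in this assay, and compound 2 `CCC(C(=O)N1CCN(c2cccc(F)c2)CC1)N1C(=O)CCC1=O` gives 75% in this assay. The two steps that lead to compound 3 are a number 25 percentage points higher from compound 1 to compound 3 (beyond the scatter) and a number 25 percentage points higher from compound 2 to compound 3 (beyond the scatter). Compound 4 `CC(C(=O)N1CCN(c2cccc(Cl)c2)CC1)N1C(=O)CCC1=O` differs from compound 3 in one place: chloro in place of fluoro on an aromatic carbon. Going by the values given here, the only measured step at this same aromatic carbon, a number 25 percentage points higher from compound 1 to compound 3 (beyond the scatter), involved an exchange of an entirely different kind, so no measured step speaks directly to swapping one halogen for another. Given that compound 3 already stands at the top of the scale with 100%, an increase beyond the scatter is not possible in this assay; the expectation for compound 4 is therefore a change that stays within the scatter, a number 10 percentage points lower from compound 3 to compound 4 (within the scatter). Compound 4 is accordingly estimated at 90% in this assay, between 70% and 100%.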

Compound 4, a percentage reported as activity, at one dose (the size of the read-out at that dose, not a potency): 75%
The estimate for compound 4 lay 15 percentage points above the measured number; measured number inside the range.
By their numbers in this assay, from the lowest: compounds 1, 2 and 4 (each within the scatter of the next); then compound 3.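

In this assay, going by these compounds alone, the only exchange of one halogen for another at this aromatic carbon gives a number 25 percentage points lower from compound 3 to compound 4 (beyond the scatter), so the higher number seen with 3-fluorophenyl does not carry over to 3-chlorophenyl. Chloro in place of methoxy gives no change at the digits printed from compound 1 to compound 4 (within the scatter), so on this core the read-out sets fluoro apart from both other groups but does not separate chloro from methoxy. Nothing available bears on why fluoro and chloro part here.

From the compounds shown here alone, how a bare hydrogen, a methyl, an amine or a carboxylic acid would fare on this aromatic carbon remains open. So does whether the gap between fluoro and chloro would persist on the longer chain that compound 2 carries.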